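The source may hold more compounds than are shown below. What is called first, only, known or untested is meant among the compounds shown, and "the series" means these compounds.

Compound 1 `CC[C@@]1(c2ccccc2)OCC[C@@H](CCNCc2ccccc2)O1` gives 20 nM in an assay on brain for displacement of a labelled ligand from Sigma non-opioid intracellular receptor 1 (Cavia porcellus); on this read-out higher numbers stand for weaker inhibition and lower numbers for stronger inhibition.
Compound 2 `CC[C@]1(c2ccccc2)OCC[C@H](CCNCc2ccccc2)O1` gives 28 nM in this assay.
Compound 3 `CC(C)(C)[C@@]1(c2ccccc2)OCC[C@@H](CCN)O1` gives only a limit of the assay, > 10000 nM, in this assay.

Compound 2 holds the highest of the two numbers shown in this assay, its nearest neighbour being compound 1, whose mirror image it is; the only measured step, a 1.4-fold higher number from compound 1 to compound 2 (0.15 log units; within the scatter), lies within the scatter, which is in keeping with the fact that compounds 1 and 2 differ only in the configuration as drawn as the sole difference between the pair. Going by the values given here, compound 3 sits at the limit described by the limit of > 10000 nM in this assay, at which 1 of the 3 values shown sits, and no single step links it to either of the others.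

Compound 4 `c1ccc(CNCC[C@H]2CCO[C@@H](c3ccccc3)O2)cc1` is the unmeasured compound. It differs from compound 2 by hydrogen in place of ethyl on a saturated ring carbon. None of the measured steps bears on this change: the one step shown concerns only configuration, and no pair differing by the ethyl alone has been measured. The expectation for this assay therefore rests on the unmeasured change itself, and a modest move towards a higher number is expected as a 2.1-fold higher number from compound 2 to compound 4 (0.33 log units; beyond the scatter), with wide uncertainty in either direction. Compound 4 is accordingly estimated at 60 nM in this assay, within a range from 15 nM to 300 nM.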

Compound 4, inhibition constant: 50 nM
Compound 4: the middle estimate sits 1.2-fold (0.08 log units) above what was measured, within the range that was stated.
By their numbers in this assay, from the lowest: compounds 1, 2 and 4 (each within the scatter of the next, the first and the last beyond it). At a limit, above all of these: compound 3.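

Going by these compounds alone, at the saturated ring carbon between two ring oxygen atoms, hydrogen in place of ethyl gives a 1.8-fold higher number from compound 2 to compound 4 (0.25 log units; within the scatter) in this assay, the first measured step at this position and the first that changes the atoms rather than the configuration. The ethyl can therefore be removed from compound 2 without a move beyond the scatter, so it is not needed for compound 4 to bind with a value in the same range in this assay. None of the available evidence bears on why this change is tolerated.

Compound 3 gives only a limit of the assay, > 10000 nM, and it differs from compound 2 in more than one place, so it cannot show what a larger group at this carbon does on its own. Going by these compounds, it remains open how a methyl, a propyl or a tert-butyl at this carbon would read with the rest of compound 2 kept, and whether the mirror image of compound 4 would stay as close to it as compound 1 does to compound 2.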